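A few compounds are considered here, and "the series" means these few. Any claim that something is new, unique, unknown or untested is made for them only; others in the source may bear on it.

Measured in an in vitro ADME assay on microsomes from liver (Mus musculus) for pharmacokinetics, read by LC-MS, with a stated time of 10 min, tested at 1 uM; a lower number here means slower removal, a higher number faster removal of the compound:
compound 1 `CN1C[C@H](C(=O)Nc2ccccc2)[C@@H](c2ccc(/C=C/C(=O)Nc3ccccc3N)cc2)C1`: 67 mL/min/kg
compound 2 `COc1ccc(NC(=O)[C@H]2CN(C)C[C@@H]2c2ccc(/C=C/C(=O)Nc3ccccc3N)cc2)cc1`: 54 mL/min/kg
compound 3 `CN1C[C@H](C(=O)Nc2ccc(C3CC3)cc2)[C@@H](c2ccc(/C=C/C(=O)Nc3ccccc3N)cc2)C1`: 60 mL/min/kg

On the numbers shown compound 2 sits at the low end of the three, but a 1.2-fold lower number from compound 1 to compound 2 (0.09 log units; within the scatter) and a 1.1-fold higher number from compound 2 to compound 3 (0.05 log units; within the scatter) are both within the scatter, so the three compounds are not separated by this assay.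

Compound 4 `CN1C[C@H](C(=O)NC2CC2)[C@@H](c2ccc(/C=C/C(=O)Nc3ccccc3N)cc2)C1` differs from compound 2 in one place: cyclopropyl in place of 4-methoxyphenyl on an amide-type nitrogen.

The steps measured so far all concern a substituent on the aromatic ring of the amide: a 1.2-fold lower number from compound 1 to compound 2 (0.09 log units; within the scatter), a 1.1-fold lower number from compound 1 to compound 3 (0.05 log units; within the scatter) and a 1.1-fold higher number from compound 2 to compound 3 (0.05 log units; within the scatter). None of them removes that ring, so they bear on the present change only loosely; what they do show is that variation at this amide has not moved the number beyond the scatter in any direction. No measured step gives a reason to expect the swap to cyclopropyl to do otherwise, so the expected step is small: a 1.1-fold lower number from compound 2 to compound 4 (0.03 log units; within the scatter), within the scatter.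

Compound 4 is therefore estimated at 50 mL/min/kg, with a range from 30 mL/min/kg to 85 mL/min/kg.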

Compound 4, clearance: 7 mL/min/kg
For compound 4 the middle estimate is 7.1-fold (0.85 log units) above the measured one, outside the stated range (below it).
By their numbers in this assay, from the lowest: compound 4; then compounds 2, 3 and 1 (each within the scatter of the next).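

In this assay, substituents on the aromatic ring of this amide left the numbers within the scatter, but cyclopropyl in place of the whole aryl group gives a 7.7-fold lower number from compound 2 to compound 4 (0.89 log units; beyond the scatter) and likewise an 8.6-fold lower number from compound 3 to compound 4 (0.93 log units; beyond the scatter) and a 9.6-fold lower number from compound 1 to compound 4 (0.98 log units; beyond the scatter) at this same amide-type nitrogen. The position is therefore not indifferent: compounds 1, 2 and 3 stay together, while compound 4 stands apart from all three, and no compound shown goes against this. Nothing shown accounts for the slower removal of compound 4.

Going by these compounds, whether the step depends on cyclopropyl itself or only on the loss of the aromatic ring remains open, and cyclohexyl or ethyl on this nitrogen would separate those two readings. Also open, on these data alone, is how a chain carrying an amine or a carboxylic acid at this nitrogen would compare in this assay with cyclopropyl.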